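The source may report more compounds than this note shows. Statements on the series, on what has been measured and on what is new or still open speak of the compounds shown alone.

Measured so far:
- compound 1, `C=CCn1c(=O)/c(=C\c2cccc(Cl)c2Cl)[nH]c(=O)/c1=C\c1ccccc1OC`: 900 nM
- compound 2, `C=CCn1c(=O)/c(=C\c2ccc(F)c(Br)c2)[nH]c(=O)/c1=C\c1ccccc1OC`: "not active" (no number reported)

In a functional assay on K562 cells (Homo sapiens) for cytotoxicity, read by CCK-8 assay, with a stated time of 72 h (a lower number here means a stronger inhibitor, a higher number a weaker inhibitor), compound 1 gives 900 nM. Compound 2 is reported in this assay only as "not active" (no number reported), so no single number places it; it stands apart from compound 1 without a measured gap. Compound 3, `C=CCn1c(=O)/c(=C\c2cc(F)ccc2C)[nH]c(=O)/c1=C\c1ccccc1OC`, has not yet been measured in this assay. It differs from compound 2 by 5-fluoro-2-methylphenyl in place of 3-bromo-4-fluorophenyl on a double-bonded chain carbon bound to an aromatic carbon. Among the compounds with values here, with no measured step between compound 2 and compound 3, and compound 2 itself lacking a number, the size of the step cannot be drawn from the data. The two measured compounds show that a change on this aryl group can move the read-out from a measured value to none at all, so a shift beyond the scatter in either direction is plausible. On that basis, compound 3 is estimated at 3000 nM, with a range of 700 nM to 20000 nM.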

Compound 3, half-maximal inhibitory concentration: 1800 nM
Beside the measured number, compound 3's estimate is 1.7-fold (0.22 log units) above it; measured number inside the range.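

The aryl group on the double-bonded chain carbon bound to an aromatic carbon now gives a number with a second substituent pattern: in this assay, 5-fluoro-2-methylphenyl in place of 2,3-dichlorophenyl gives a 2.0-fold higher number from compound 1 to compound 3 (0.30 log units; within the scatter), so a measured value here is not confined to the group of compound 1. The 3-bromo-4-fluorophenyl group of compound 2 remains the exception, reported as "not active" (no number reported), and any step from compound 2 cannot be read as a size. No evidence at hand explains why compound 2 stands apart.

The compounds shown leave open whether the methyl group, the bromine or the placing of the fluorine separates compound 2 from compound 3, since these two groups differ in several features at once. They also leave open whether an aryl group carrying an amine or a carboxylic acid at this place would still give a number.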